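The source may hold more compounds than are shown below. What is called first, only, known or untested is meant among the compounds shown, and "the series" means these compounds.

Three compounds sharing one core are at issue: compound 1 `COc1ccc(-n2c(-c3cc(OC)c(OC)c(OC)c3)csc2=O)cc1`, compound 2 `COc1ccc(-n2c(-c3cc(OC)c(OC)c(OC)c3)csc2=O)cc1[N+](=O)[O-]` and compound 3 `COc1ccc(-n2c(-c3cc(OC)c(OC)c(OC)c3)csc2=O)cc1N`. For the measured compounds named here, in a functional assay on CCRF-CEM cells (Homo sapiens) for antiproliferative activity, with a stated time of 72 h (on this read-out lower numbers stand for stronger inhibition and higher numbers for weaker inhibition), compound 1 gives 14900 nM and compound 2 gives 2700 nM, so compound 2 holds the lower of the two numbers measured so far. Compound 3 keeps the core and alters one group of compound 2: amino in place of nitro on an aromatic carbon, ortho to a methoxy group and meta to a large group (amino in place of nitro on an aromatic carbon). Going by the values given here, only one measured step bears on this change. Nitro in place of hydrogen on that same carbon brought a 5.5-fold lower number from compound 1 to compound 2 (0.74 log units; beyond the scatter), a modest step. Among the compounds with values here, that step compares nitro with hydrogen, and no measurement yet compares amino with nitro, so the direction remains uncertain. A modest further fall in this assay is nevertheless expected, of similar size to that single step. The estimated change is a 3.4-fold lower number from compound 2 to compound 3 (0.53 log units; beyond the scatter). For compound 3 the expected value is 800 nM, with an estimated range from 60 nM to 7000 nM.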

Compound 3, half-maximal inhibitory concentration: 10100 nM
The estimate for compound 3 lay 13-fold (1.10 log units) below the measured number; the whole stated range lies below it.
By their numbers in this assay, from the lowest: compound 2; then compounds 3 and 1 (each within the scatter of the next).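

In this assay the gain seen at this aromatic carbon does not carry over from nitro to amino: amino in place of nitro brings a 3.7-fold higher number from compound 2 to compound 3 (0.57 log units; beyond the scatter) and so takes back most of what nitro had given. Amino in place of hydrogen brings a 1.5-fold lower number from compound 1 to compound 3 (0.17 log units; within the scatter) and thus leaves amino and hydrogen not separable at this carbon, ortho to a methoxy group, so among the three groups compared here only nitro stands apart. The data at hand offer no measured property that would account for this split between nitro and amino.

The three compounds leave open whether the lower number is peculiar to nitro or would also appear with other groups on this carbon, such as a nitrile, a carboxylic acid or an acetamide. They also leave open whether the same ranking of nitro, amino and hydrogen would hold if the neighbouring methoxy group gave way to a hydroxyl or a chlorine atom.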